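The compounds below may be only part of what the source reports. "The series", "measured", "known", "first", "only" and "open" are said of these compounds alone.

Compound 1 `C#CCNC1CCc2c(SCCc3ccc(Br)cc3)cccc21` and compound 2 `C#CCNC1CCc2c(OCc3cccc(C(F)(F)F)c3)cccc21` share a core and were examined in an ADME assay on isolated protein for inhibition of Amine oxidase [flavin-containing] B (Homo sapiens); on this read-out higher numbers stand for weaker inhibition and lower numbers for stronger inhibition. In this assay compound 1 gives 1250 nM, the lower of the two numbers. In this assay compound 2 gives 5410 nM, a number that lies beyond the usual scatter from what compound 1 shows. Compound 3 `C#CCNC1CCc2c(SCCc3cccc(C)c3)cccc21` has not yet been measured in this assay. It differs from compound 1 in one place: 3-methylphenyl in place of 4-bromophenyl on a saturated chain carbon, two bonds along the chain from a sulfur. Among the measured compounds shown here, no pair of measured compounds that differ in a single place is available. The existing numbers do not show what this change does. In this assay the expected step is a 2.0-fold higher number from compound 1 to compound 3 (0.30 log units; within the scatter), modest in size and toward a higher number, though it may also stay within the scatter. Compound 3 is therefore estimated to give about 2500 nM in this assay, with a range from 800 nM to 8000 nM.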

Compound 3, half-maximal inhibitory concentration: 4960 nM
The estimate for compound 3 lay 2.0-fold (0.30 log units) below the measured number; the measured number falls inside the stated range.
By their numbers in this assay, from the lowest: compound 1; then compounds 3 and 2 (each within the scatter of the next).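

In this assay, among the compounds shown here, this is the first comparison in which compounds differ in only one place, and it gives a 4.0-fold higher number from compound 1 to compound 3 (0.60 log units; beyond the scatter). The group carried on a saturated chain carbon, two bonds along the chain from a sulfur, therefore affects the read-out even though 4-bromophenyl and 3-methylphenyl have the same count of heavy atoms and neither has a hydrogen-bond donor or acceptor. No measurement available here accounts for this step.

As far as these compounds go, the swap changes both the substituent and its place on the ring, so it remains open which of the two matters; a 4-methylphenyl or a 3-bromophenyl group would separate them. From the compounds shown here alone, it is also open how an unsubstituted phenyl, a 4-chlorophenyl or a longer chain would read at this position.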